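Ester replacement at the cinnamoyl terminus: gastric half-life series

A few compounds are considered here, and "the series" means these few. Any claim that something is new, unique, unknown or untested is made for them only; others in the source may bear on it.

Measured so far in an ADME assay on stomach for pharmacokinetics, in simulated gastric fluid; on this read-out lower numbers stand for a shorter-lived compound and higher numbers for a longer-lived compound:
- compound 1 `CCOc1cc(NC(=O)C2(NC(=O)c3ccc4c(C5CCCC5)c(-c5ncc(Cl)cn5)n(C)c4c3)CCC2)ccc1/C=C/C(=O)N[C@@H](CCC(=O)O)C(N)=O` gives 0.533 h
- compound 2 `CCOc1cc(NC(=O)C2(NC(=O)c3ccc4c(C5CCCC5)c(-c5ncc(Cl)cn5)n(C)c4c3)CCC2)ccc1/C=C/C(=O)N[C@@H](CCCNC(=N)N)C(N)=O` gives 0.467 h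
- compound 3 `CCOc1cc(NC(=O)C2(NC(=O)c3ccc4c(C5CCCC5)c(-c5ncc(Cl)cn5)n(C)c4c3)CCC2)ccc1/C=C/C(=O)OCc1ccccc1` gives 1.83 h

Compound 1 stands second highest of the three numbers. Its nearest neighbour is compound 2, with a 1.1-fold lower number from compound 1 to compound 2 (0.06 log units; within the scatter). Among the compounds with values here, the one step beyond the scatter runs to the benzyl ester, a 3.4-fold higher number from compound 1 to compound 3 (0.54 log units; beyond the scatter); the parallel step a 3.9-fold higher number from compound 2 to compound 3 (0.59 log units; beyond the scatter) reads the same way, so the common feature of both larger steps is the exchange of an amide for an ester on this carbonyl carbon.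

Compound 4 `CCOc1cc(NC(=O)C2(NC(=O)c3ccc4c(C5CCCC5)c(-c5ncc(Cl)cn5)n(C)c4c3)CCC2)ccc1/C=C/C(=O)OCC(N)=O` is not yet measured. It differs from compound 1 in one place: carbamoylmethoxy in place of (1-carbamoyl-3-carboxypropyl)amino on a carbonyl carbon

This is again an amide-to-ester exchange at the same carbonyl carbon, so a 3.4-fold higher number from compound 1 to compound 3 (0.54 log units; beyond the scatter) is the step that bears on it. Within the data shown here, compound 4 carries a smaller entering group than compound 3, and no measured pair shows how the size of the ester group itself matters, so the expected step is placed somewhat short of that seen for compound 3. For compound 4 the number is expected to rise, a 2.1-fold higher number from compound 1 to compound 4 (0.31 log units; beyond the scatter). Compound 4 is therefore estimated at 1.1 h, with a range from 0.55 h to 2.2 h.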

Compound 4, half-life: 0.6 h
For compound 4 the middle estimate is 1.8-fold (0.26 log units) above the measured one; the range from low to high includes it.
By their numbers in this assay, from the lowest: compounds 2, 1 and 4 (each within the scatter of the next); then compound 3.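

In this assay the exchange of amide for ester on this carbonyl carbon does not on its own go with a longer half-life: a 1.1-fold higher number from compound 1 to compound 4 (0.05 log units; within the scatter) and a 1.3-fold higher number from compound 2 to compound 4 (0.11 log units; within the scatter), so compound 4 is an ester whose number stays level with those of both amides. The change that matters among the esters is carbamoyl in place of phenyl, with a 3.1-fold lower number from compound 3 to compound 4 (0.48 log units; beyond the scatter), so compound 4 goes against the amide-to-ester reading that compound 3 alone had supported. Nothing available here accounts for the gap between the two esters.

From the compounds shown here alone, it stays open whether the ring of compound 3 or the ester linkage paired with it sets the higher number, which a benzylamide at this carbonyl carbon would separate. Simple methyl and ethyl esters would show where small groups without a carbamoyl fall.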